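Ring Exchange on the Carbonyl: From Compound 3 to Compound 4

The compounds below may be only part of what the source reports. "The series", "measured", "known", "first", "only" and "open" are said of these compounds alone.

Compound 1 `CN1CCN(CCCS(=O)(=O)c2ccc3nc(NC(=O)NC(=O)c4cc(N5CCCC5)c(C#N)cc4Cl)sc3c2)CC1` gives 0.24 nM in an assay on HEK293 cells for displacement of a labelled ligand from growth hormone secretagogue receptor type 1 (Homo sapiens), with a stated time of 60 min; a higher number here means a weaker inhibitor, a lower number a stronger inhibitor.
Compound 2 `Cc1cc(C)n(-c2ccc(Cl)c(C(=O)NC(=O)Nc3nc4ccc(S(=O)(=O)CCCN5CCN(C)CC5)cc4s3)c2)n1` gives 1.3 nM in this assay.
Compound 3 `CN1CCN(CCCS(=O)(=O)c2ccc3nc(NC(=O)NC(=O)c4cccc(-n5cccn5)c4Cl)sc3c2)CC1` gives 8.8 nM in this assay.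

Of these three numbers, compound 3 has the highest; compound 2 stands below it by a gap beyond the scatter, and compound 1 lies further below still. Compound 4 `CN1CCN(CCCS(=O)(=O)c2ccc3nc(NC(=O)NC(=O)c4cc(N5CCCC5)ccc4Cl)sc3c2)CC1` has not yet been measured in this assay. It differs from compound 3 in a single place: 2-chloro-5-(pyrrolidin-1-yl)phenyl in place of 2-chloro-3-(1H-pyrazol-1-yl)phenyl on a carbonyl carbon. Among the measured compounds shown here, no measured step connects the two. Because compound 1 gives 0.24 nM and compound 2 gives 1.3 nM, both well below compound 3, the step of a 15-fold lower number from compound 3 to compound 4 (1.17 log units; beyond the scatter) is expected to be a decrease beyond the scatter. For compound 4 the estimated value is 0.6 nM, with a range from 0.15 nM to 2.5 nM.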

Compound 4, half-maximal inhibitory concentration in the growth hormone secretagogue receptor type 1 assay: 0.29 nM
The estimate for compound 4 lay 2.1-fold (0.32 log units) above the measured number, within the range that was stated.
By their numbers in the growth hormone secretagogue receptor type 1 assay, from the lowest: compounds 1 and 4 (each within the scatter of the next); then compound 2; then compound 3.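

In the growth hormone secretagogue receptor type 1 assay the ring exchange on the carbonyl carbon gives a 30-fold lower number from compound 3 to compound 4 (1.48 log units; beyond the scatter), and pyrrolidin-1-yl in place of 3,5-dimethyl-1H-pyrazol-1-yl on an aromatic carbon gives a 4.5-fold lower number from compound 2 to compound 4 (0.65 log units; beyond the scatter). In the growth hormone secretagogue receptor type 1 assay hydrogen in place of cyano on an aromatic carbon gives a 1.2-fold higher number from compound 1 to compound 4 (0.08 log units; within the scatter), so the assay does not separate these two compounds. In a physicochemical assay for lipophilicity (on this read-out lower numbers stand for lower lipophilicity and higher numbers for higher lipophilicity), compound 3 gives 1.6 and compound 4 gives 3.1, so the same exchange also raises lipophilicity: the measured distribution coefficient of compound 3, 1.6, and of compound 4, 3.1, a number 1.50 log units higher (beyond the scatter)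

The compounds shown do not tell whether the two read-outs move together beyond this one pair. From the compounds shown here alone, whether morpholin-4-yl or a dimethylamino group in place of pyrrolidin-1-yl would hold the number in the growth hormone secretagogue receptor type 1 assay remains open.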